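Sulfonyl aryl swap: trifluoromethyl position and microsomal stability

The source may hold more compounds than are shown below. What is called first, only, known or untested is meant among the compounds shown, and "the series" means these compounds.

Working notes on a pair of sulfonamides sharing one core. For the measured compounds named here, compound 1 `CN1Cc2cc(-c3ccc(-c4cncc(NS(=O)(=O)c5cccc(C(F)(F)F)c5)c4)s3)cnc2C1=O` is the less stable of the two measured members: in an ADME assay on microsomes from liver (Homo sapiens) for metabolic stability, read by LC-MS, using NADPH, with a stated time of 30 min, tested at 3 uM (on this read-out higher numbers stand for a more stable compound and lower numbers for a less stable compound), compound 1 gives 46%, the lowest of the two numbers, while compound 2 `COc1ncc(-c2ccc(-c3cnc4c(c3)CN(C)C4=O)s2)cc1NS(=O)(=O)c1ccccc1[N+](=O)[O-]` gives 94%, a gap beyond the scatter. Compound 2 differs from compound 1 in more than one place, so no single change can be read from that gap. Compound 3 `CN1Cc2cc(-c3ccc(-c4cncc(NS(=O)(=O)c5ccccc5C(F)(F)F)c4)s3)cnc2C1=O` is not yet measured. It differs from compound 1 in one place only, the same atoms joined differently: 2-(trifluoromethyl)phenyl in place of 3-(trifluoromethyl)phenyl on a sulfonyl sulfur. Going by the values given here, no measured pair in this set shows what this change does. The estimated step is a number 4 percentage points higher from compound 1 to compound 3 (within the scatter), expected to lie within the scatter rather than beyond it. On that basis compound 3 is expected to give about 50% in this assay, within 30% to 72%.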

Compound 3, percent of the compound remaining: 56%
The estimate for compound 3 lay 6 percentage points below the measured number; measured number inside the range.
By their numbers in this assay, from the lowest: compounds 1 and 3 (each within the scatter of the next); then compound 2.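

For the compounds shown here, on a sulfonyl sulfur whose other neighbour is the sulfonamide nitrogen, 2-(trifluoromethyl)phenyl in place of 3-(trifluoromethyl)phenyl gives the first single-place step in this set: in this assay, the step is a number 10 percentage points higher from compound 1 to compound 3 (within the scatter), so moving the trifluoromethyl group around this ring does not separate the two compounds on this read-out. The shared core and sulfonamide nitrogen are unchanged in this pair, which isolates the aryl substitution from the other differences carried by compound 2. No supporting data bear on why the step has this size.

Still open, from the compounds shown here alone, is whether a different group on this phenyl ring, such as a nitrile, an amine or a carboxylic acid, would give a step beyond the scatter. The separate contributions of the differences between compound 1 and compound 2 also remain unresolved.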